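The source may report more compounds than this note shows. Statements on the series, on what has been measured and on what is new or still open speak of the compounds shown alone.

Compound 1, `CCC1(Cc2ccccc2)OS(=O)(=O)C=C1OCc1ccc(OC)cc1`, stands in an ADME assay on HEL cells (Homo sapiens) for cytotoxicity, with a stated time of 3 days (on this read-out lower numbers stand for higher toxicity in this test and higher numbers for lower toxicity in this test), at a limit of the assay, >= 200000 nM, which is the limit of >= 200000 nM in this assay, at which 1 of the 3 values shown sits. Compound 2, `CCC1(Cc2ccccc2)OS(=O)(=O)C=C1OC`, likewise reaches a limit in this assay, > 400000 nM, which is the limit of > 400000 nM in this assay, at which 1 of the 3 values shown sits. Compound 3, `CCC1(Cc2ccccc2)OS(=O)(=O)C=C1OCC=C(C)C`, gives a number in this assay, 400000 nM. As far as these compounds go, the step that the two limits leave unreadable from compound 1 to compound 2 and the step that the limit leaves unreadable from compound 1 to compound 3 leave nothing to read, and the step of a number no higher from compound 2 to compound 3 (the limit leaves the size open) is likewise open in size. Compound 4, `CCC1(Cc2ccccc2)OS(=O)(=O)C=C1OCc1ccc(C(F)(F)F)cc1`, carries trifluoromethyl in place of methoxy on an aromatic carbon. Of the measured steps, those starting from compound 1 are the ones that bear on this change, yet both begin at its limit and end at a limit or at a number of the same order, and none of them alters the aromatic substituent that changes here. The values of compound 1, compound 2 and compound 3 all sit at or close to the upper edge of this assay, so no step beyond the scatter is expected, and a limit rather than a number is the likeliest outcome for compound 4. Compound 4 is therefore estimated at 200000 nM, within 100000 nM to 400000 nM. The expected step is a number no higher from compound 1 to compound 4 (the limit leaves the size open).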

Compound 4, minimum cytotoxic concentration: >= 16000 nM
Compound 4 ended at the assay's limit; the forecaster's own chance of this, stated with the estimate: 70%; the middle value does not contradict the limit.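

Compound 1 and compound 4 both stand at limits of this assay, and the step between them cannot be read. The compounds shown leave open whether trifluoromethyl in place of methoxy on the aromatic carbon changes the minimum cytotoxic concentration at all, and in which direction.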